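The source may report more compounds than this note shows. Statements on the series, on what has been measured and on what is new or still open speak of the compounds shown alone.

Measured so far:
Compound 1 `Oc1ccc(-c2cc(-c3cccs3)cc(-c3ccccc3O)n2)cc1` gives > 50000 nM in a functional assay on HCT-15 cells (Homo sapiens) for cytotoxicity, read by CCK-8 assay; on this read-out lower numbers stand for stronger inhibition and higher numbers for weaker inhibition.
Compound 2 `Oc1cccc(-c2cc(-c3ccsc3)cc(-c3ccccc3O)n2)c1` gives > 50000 nM in this assay.

Neither number is a true measurement. For compound 1 the value > 50000 nM is a limit of the assay, meaning no inhibition was seen up to that concentration. For compound 2 the value > 50000 nM is likewise a limit. So compound 2 stands nowhere in particular on a scale of potency: it and the only other compound share the same limit, (the limit of > 50000 nM in this assay, at which 2 of the 2 values shown sit).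

Compound 3 `Oc1ccc(-c2cc(-c3ccsc3)cc(-c3ccccc3O)n2)cc1` has not yet been tested. It differs from compound 2 by 4-hydroxyphenyl in place of 3-hydroxyphenyl on an aromatic carbon; the two have the same atoms, joined differently. Among the measured compounds shown here, with no measured step between compounds to lean on, the change from compound 2 to compound 3 is expected to make no difference beyond the scatter, a step that the limit leaves unreadable from compound 2 to compound 3, because both values so far sit at the limit of > 50000 nM in this assay, at which 2 of the 2 values shown sit. Compound 3 is therefore expected to give about 70000 nM, somewhere between 25000 nM and 200000 nM, most likely reported again only as a limit.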

Compound 3, half-maximal inhibitory concentration: > 50000 nM
Compound 3: no number, only a limit; the forecaster's own chance of this, stated with the estimate: 85%; the middle value is on the limit's open side.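

Among the compounds shown here, no step between compound 1, compound 2 and compound 3 can be read, because each value is only a limit: the limit of > 50000 nM in this assay, at which 3 of the 3 values shown sit.

The compounds shown leave open whether exchanging 3-hydroxyphenyl for 4-hydroxyphenyl, or thiophen-2-yl for thiophen-3-yl, changes potency at all.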